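A Second Aryl Group on the Shared Core

A few compounds are considered here, and "the series" means these few. Any claim that something is new, unique, unknown or untested is made for them only; others in the source may bear on it.

In an ADME assay on microsomes from liver (Homo sapiens), read by LC-MS, using NADPH, with a stated time of 30 min, tested at 1 uM (a higher number here means that more of the compound is left, a lower number that less of the compound is left), compound 1 , `C[C@H](Nc1ncnc2[nH]cnc12)c1cc2ccc(F)cn2c(=O)c1-c1ccccc1`, gives 98%. For compound 2 , `C[C@H](Nc1ccnc(N)n1)c1cc2ccc(F)cn2c(=O)c1-c1ccccc1`, the result in this assay is "not determined" (no result reported). Compound 3 , `Cc1nc(N)nc(N[C@@H](C)c2cc3ccc(F)cn3c(=O)c2-c2ccccc2)c1C#N`, gives 83% in this assay. Among the measured compounds shown here, the one measured step, a number 15 percentage points lower from compound 1 to compound 3 (beyond the scatter), leaves compound 3 as the lowest of the two numbers, with compound 1 standing above it.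

Compound 4 , `Cc1nc(N)nc(N[C@@H](C)c2c(-c3ccccc3)c(=O)n3cc(F)ccc3c2-c2ccc(F)cc2)c1C#N`, differs from compound 3 by 4-fluorophenyl in place of hydrogen on an aromatic carbon. For the measured compounds named here, no measured step bears on this kind of change: the only step in this assay exchanges the group on the amine nitrogen and says nothing about a group added to the shared core. With nothing to lean on, compound 4 is expected to keep most of the compound remaining, and the step of a number 13 percentage points lower from compound 3 to compound 4 (beyond the scatter) is estimated to fall within or only slightly beyond the scatter, downward if anything. For compound 4 the estimate in this assay is 70%, with a range from 45% to 92%.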

Compound 4, percent of the compound remaining: 91%
Beside the measured number, compound 4's estimate is 21 percentage points below it; low and high end bracket the measured number.
By their numbers in this assay, from the lowest: compounds 3, 4 and 1 (each within the scatter of the next, the first and the last beyond it).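

Among the compounds shown here, until now the only measured step exchanged the group on the amine nitrogen; compound 4 gives the first reading at this aromatic carbon of the shared core, two atoms from the ring nitrogen. In this assay, placing 4-fluorophenyl there in place of hydrogen gives a number 8 percentage points higher from compound 3 to compound 4 (within the scatter), so this large addition to the core produces no change beyond the scatter in the percent of compound remaining. Nothing measured here explains this outcome.

The compounds shown leave open whether other groups on this carbon, such as methyl, a morpholine or a carboxylic acid, would also read within the scatter of compound 3. For the compounds shown here, they also leave open whether 4-fluorophenyl would give the same result with the amine group of compound 1 in place of the one shared by compound 3 and compound 4.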